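The source may report more compounds than this note shows. Statements on the series, on what has been measured and on what is new or still open speak of the compounds shown alone.

In an assay on HEK293 cells for displacement of a labelled ligand from Neuronal acetylcholine receptor; alpha3/beta4 (Homo sapiens), read by radioligand binding, with a stated time of 5 min (on this read-out higher numbers stand for weaker inhibition and lower numbers for stronger inhibition), compound 2 `Brc1cccc(C2=NCCCC2)c1` gives 29.8 nM, the lowest of the two numbers recorded so far. Its nearest neighbour is compound 1 `OCc1cc(F)cc(C2=NCCCC2)c1`, which in this assay gives 80 nM; the gap between the two lies beyond the usual scatter, so compound 2 is the stronger binder of the pair on these data.

The step to compound 3 `Fc1cccc(C2=NCCCC2)c1` consists of one change: fluoro in place of bromo on an aromatic carbon. Among the measured compounds shown here, no pair of measured compounds shows this exchange on its own, so its effect is not known from the data; compound 1 carries a fluoro as well, but also a hydroxymethyl, so it does not isolate the change.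

Compound 3 is expected to bind somewhat more weakly than compound 2, with the step from compound 2 to compound 3 estimated at a 2.0-fold higher number from compound 2 to compound 3 (0.30 log units; within the scatter), a modest rise that may well stay near the edge of the scatter. In this assay compound 3 is therefore expected to give about 60 nM, with a range from 25 nM to 150 nM.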

Compound 3, inhibition constant: 108 nM
Compound 3: middle estimate off by 1.8-fold (0.26 log units), on the low side; measured number inside the range.
By their numbers in this assay, from the lowest: compound 2; then compounds 1 and 3 (each within the scatter of the next).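

On this aromatic carbon, the halogen exchange now has a measured size in this assay: fluoro in place of bromo gives a 3.6-fold higher number from compound 2 to compound 3 (0.56 log units; beyond the scatter) and so costs binding. The hydroxymethyl of compound 1 can also be read on its own, since hydrogen in its place gives a 1.4-fold higher number from compound 1 to compound 3 (0.13 log units; within the scatter) and leaves the two compounds indistinguishable on these data. Of the two single changes now measured, only the exchange of bromo for fluoro moves the number beyond the scatter.

No measurement shown here gives a reason for either step. Going by these compounds, it remains open whether chloro or methoxy on the same aromatic carbon would fall nearer to bromo or to fluoro, and whether an amine or a carboxylic acid in place of the hydroxymethyl would matter more than that group does.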